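A few compounds are considered here, and "the series" means these few. Any claim that something is new, unique, unknown or untested is made for them only; others in the source may bear on it.

Compound 1 `CC1=C(C(=O)CC(C)C)C(c2ccoc2)NC(=O)N1` is the reference point here. Among the measured compounds shown here, in an assay on membranes from HeLa cells for displacement of a labelled ligand from adenosine receptor A3 (Homo sapiens), read by scintillation counting, with a stated time of 180 min, tested at 1 uM (a higher number here means more inhibition at the concentration tested (going by the name of the read-out), a lower number less inhibition), compound 1 gives 18% and stands highest of the two numbers known, though compound 2 `CC1=C(C(=O)CC(C)C)C(c2ccsc2)NC(=O)N1`, which gives 14%, lies close: the change a number 4 percentage points lower from compound 1 to compound 2 (within the scatter) brings a thiophen-3-yl in place of a furan-3-yl. Compound 3 `CC1=C(C(=O)SC(C)C)C(c2ccoc2)NC(=O)N1` differs from compound 1 in another spot: isopropylsulfanyl in place of isobutyl on a carbonyl carbon. For the measured compounds named here, no measured step touches this position, so nothing in the data points to a direction. Compound 3 is therefore expected to land near compound 1, with a step of a number 1 percentage points lower from compound 1 to compound 3 (within the scatter) not beyond the scatter, giving an estimate of 17% within 5% to 32%.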

Compound 3, a percentage reported as inhibition, at one concentration (the size of the read-out at that concentration, not a potency): 3%
Estimate against measurement, compound 3: 14 percentage points above; measured number outside the range, below it.
By their numbers in this assay, from the lowest: compound 3; then compounds 2 and 1 (each within the scatter of the next).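

Unlike the thiophen-3-yl change, this change shows that the number responds to what sits on the carbonyl carbon: in this assay, isopropylsulfanyl in place of isobutyl brings a number 15 percentage points lower from compound 1 to compound 3 (beyond the scatter). The two groups have the same count of heavy atoms, and they differ in a sulfur taking the place of a carbon and in the hydrogen-bond acceptor counted for isopropylsulfanyl. Nothing at hand accounts for this drop.

On these data alone, it remains open whether the sulfur or the shape of the chain matters here, and whether an amine or a longer alkyl chain on this carbonyl carbon would keep, lower or raise the number.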